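The source may report more compounds than this note shows. Statements on the series, on what has been measured and on what is new or still open speak of the compounds shown alone.

Measured so far in a functional assay on the whole organism (blood, strain albino) with Mus musculus as the target, with stated times of 6 days and 4 h, at a dose of 0.4 mmol/kg by the oral route; on this read-out lower numbers stand for less inhibition and higher numbers for more inhibition at the one dose given (going by the name of the read-out):
compound 1 `Cc1cc(C(=O)O)nn1-c1ccc(S(=O)(=O)NC(=O)NCc2ccccc2)cc1` gives 0%
compound 2 `Cc1cc(C)n(-c2ccc(S(=O)(=O)NC(=O)NC3CCCCC3)cc2)n1` gives 10%
compound 3 `CCCCNC(=O)NS(=O)(=O)c1ccc(-n2nc(C)cc2C)cc1` gives 2%

Compound 3 stands second highest of the three numbers; compound 1 is nearest and compound 2 furthest, both within the scatter, so no order among them can be read.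

Compound 4 `Cc1cc(C)n(-c2ccc(S(=O)(=O)NC(=O)NCc3ccccc3)cc2)n1` differs from compound 3 by phenyl in place of propyl on a saturated chain carbon bound to an amide-type nitrogen. Going by the values given here, the one step that bears on this is a number 8 percentage points lower from compound 2 to compound 3 (within the scatter), a change on the same amide-type nitrogen that stayed within the scatter. Among the compounds with values here, no measured pair replaces propyl by phenyl; compound 1 carries benzyl on a different core and gives 0%, also low. The expected step is therefore a number 1 percentage points higher from compound 3 to compound 4 (within the scatter), none beyond the scatter. Compound 4 is estimated at 3%, range 0% to 12%.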

Compound 4, a percentage reported as inhibition, in the whole organism at one dose (the size of the read-out at that dose, not a potency): < 1%
Compound 4: no number, only a limit; the forecaster's own chance of this, stated with the estimate: 0%; middle value at least 2 percentage points from the limit.
By their numbers in this assay, from the lowest: compounds 1, 3 and 2 (each within the scatter of the next).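

In this assay compound 4 gives < 1%, which is a limit of the assay and not a number. Phenyl in place of propyl gives a number at least 1 percentage points lower from compound 3 to compound 4 (that floor lies within the scatter), and benzyl in place of cyclohexyl gives a number at least 9 percentage points lower from compound 2 to compound 4 (that floor lies within the scatter); both floors lie within the scatter, so on the shared core an aromatic ring at this place separates from neither butyl nor cyclohexyl. The step between compound 1 and compound 4 cannot be read.

Open, going by these compounds, is whether an amine or a carboxylic acid on the phenyl, or a longer chain on the amide-type nitrogen, moves this assay beyond the scatter.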